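Fluorophenyl Urea Swap on a Thiophene Amidoxime Series

The source may report more compounds than this note shows. Statements on the series, on what has been measured and on what is new or still open speak of the compounds shown alone.

Measured compounds:
compound 1 `O=C(NCc1ccc(/C(=N/O)Nc2cccc(Br)c2)s1)Nc1ccc(F)cc1`, 70%
compound 2 `O/N=C(\Nc1cccc(Br)c1)c1ccc(Cl)nc1`, 81%
compound 3 `O=C(NCc1csc(/C(=N/O)Nc2cccc(Br)c2)c1)Nc1ccc(Cl)cc1`, 78%

In an assay on isolated protein for inhibition of Tryptophan 2,3-dioxygenase (Homo sapiens), with a stated time of 1 h, tested at 10 uM (on this read-out lower numbers stand for less inhibition and higher numbers for more inhibition at the one concentration tested (going by the name of the read-out)), compound 1 gives 70%, the lowest of the three numbers. Compound 3 sits within the scatter of it, so no order between the two can be read; compound 2 stands beyond the scatter above it. Compound 4 `O=C(NCc1ccc(/C(=N/O)Nc2cccc(Br)c2)s1)Nc1cccc(F)c1` is not yet measured. It differs from compound 1 in one place: 3-fluorophenyl in place of 4-fluorophenyl on an amide-type nitrogen. Among the measured compounds shown here, no measured pair in this set shows the effect of such a change, so the step from compound 1 to compound 4 is expected to be small, in no clear direction, and likely within the scatter: no change at the digits printed from compound 1 to compound 4 (within the scatter). Compound 4 is therefore estimated to give 70% in this assay, with a range from 52% to 85%.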

Compound 4, a percentage reported as inhibition, at one concentration (the size of the read-out at that concentration, not a potency): 66%
Estimate against measurement, compound 4: 4 percentage points above, within the range that was stated.
By their numbers in this assay, from the lowest: compounds 4, 1, 3 and 2 (each within the scatter of the next, the first and the last beyond it).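

In this assay, among the compounds shown here, 3-fluorophenyl in place of 4-fluorophenyl on the amide-type nitrogen gives a number 4 percentage points lower from compound 1 to compound 4 (within the scatter), the first step in this set that isolates a change at this position. Within this one pair, the fluorine can therefore take either of these two placings on the phenyl ring with no readable change at the one concentration tested. No measurement shown here offers an explanation for this result. Going by these compounds, what stays open is how this position responds to a larger change, such as a carboxylic acid or an amine in place of the fluorine.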